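Trifluoromethyl for fluoro on the dihalophenyl series

A few compounds are considered here, and "the series" means these few. Any claim that something is new, unique, unknown or untested is made for them only; others in the source may bear on it.

In a functional assay on SW-620 cells (Homo sapiens) (a higher number here means a weaker inhibitor of growth, a lower number a stronger inhibitor of growth), three compounds sharing one core have been measured. Compound 2 `O=S(=O)(/C=C/c1ccc(Cl)cc1Cl)Cc1ccc(Nc2ncnc3ccccc23)cc1` gives 14000 nM. Compound 3 `O=S(=O)(/C=C/c1ccc(F)cc1F)Cc1ccc(Nc2ncnc3ccccc23)cc1` gives 86000 nM, the higher of the two exact numbers. For compound 1 `O=S(=O)(/C=C/c1ccc(Br)cc1)Cc1ccc(Nc2ncnc3ccccc23)cc1` the assay reports only a limit, > 100000 nM.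

Compound 4 `O=S(=O)(/C=C/c1ccc(C(F)(F)F)cc1F)Cc1ccc(Nc2ncnc3ccccc23)cc1` differs from compound 3 at a single place trifluoromethyl in place of fluoro on an aromatic carbon: trifluoromethyl stands in place of fluoro on an aromatic carbon, meta to a fluoro group and para to a large group, so that 2,4-difluorophenyl becomes 2-fluoro-4-(trifluoromethyl)phenyl.

For the measured compounds named here, no measured compound carries trifluoromethyl, so the evidence is indirect. The closest step is a 6.1-fold higher number from compound 2 to compound 3 (0.79 log units; beyond the scatter), which exchanges the 2,4-dichlorophenyl group for the 2,4-difluorophenyl group. The steps from the 4-bromophenyl group are an at least 7.1-fold lower number from compound 1 to compound 2 (0.85 log units; beyond the scatter) and an at least 1.1-fold lower number from compound 1 to compound 3 (0.06 log units; that floor lies within the scatter). Compound 1 goes against any simple reading that a heavier group at this place lowers the number. A step toward a lower number is therefore expected, but one smaller than the gap separating compound 2 from compound 3. The estimated step is a 2.2-fold lower number from compound 3 to compound 4 (0.33 log units; beyond the scatter). For compound 4 the estimated value is 40000 nM, with an expected range of 12000 nM to 100000 nM.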

Compound 4, concentration for 50% growth inhibition: 100000 nM
Estimate against measurement, compound 4: 2.5-fold (0.40 log units) below; the range from low to high includes it.
By their numbers in this assay, from the lowest: compound 2; then compounds 3 and 4 (each within the scatter of the next).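

In this assay, trifluoromethyl in place of fluoro on an aromatic carbon, para to a large group, gives a 1.2-fold higher number from compound 3 to compound 4 (0.07 log units; within the scatter), so trifluoromethyl, a group of 4 heavy atoms, and fluoro, a group of 1 heavy atom, cannot be told apart here. The 2,4-dichlorophenyl group of compound 2 now stands apart from two other aryl groups rather than one, with a 7.1-fold higher number from compound 2 to compound 4 (0.85 log units; beyond the scatter) alongside the earlier 6.1-fold higher number from compound 2 to compound 3 (0.79 log units; beyond the scatter), while compounds 3 and 4 stay within the scatter of each other. The remaining step, a number no higher from compound 1 to compound 4 (the limit leaves the size open), cannot be read for its size, since its starting value is only a limit: the limit of > 100000 nM in this assay, at which 1 of the 4 values shown sits.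

The compounds shown leave open whether the lower number of compound 2 depends on the chloro group at one place or on both, which a 4-chloro-2-fluorophenyl or a 2-chloro-4-(trifluoromethyl)phenyl group would help to separate. They also leave open how a methoxy group, a nitrile or an amine at this aromatic carbon would read in this assay.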